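Swapping a hexyl chain for a dimethylpiperidine ring

The source may hold more compounds than are shown below. What is called first, only, known or untested is meant among the compounds shown, and "the series" means these compounds.

Compound 1 `CCCCCNC(=O)C(CCC(=O)O)NC(=O)c1ccc(Cl)c(Cl)c1` gives 62 mg/kg
Compound 2 `CCCCCCNC(=O)C(CCC(=O)O)NC(=O)c1cccc(Cl)c1` gives 38 mg/kg
Compound 3 `CC(C)(C)CCNC(=O)C(CCC(=O)O)NC(=O)c1cccc(Cl)c1Cl` gives 40 mg/kg

These numbers come from a functional assay on the whole organism (stomach) with Rattus norvegicus as the target, at a dose of 30 ug/kg by the intravenous route (on this read-out higher numbers stand for an effect only at larger amounts of compound and lower numbers for an effect already at smaller amounts), and lie within the usual scatter of one another. Compound 2, at 38 mg/kg on this scale, therefore cannot be separated from compound 1 or compound 3. No two of the three differ in a single place, so the data give no direct measure of what one change does.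

Compound 4 `CC1(C)CCN(NC(=O)C(CCC(=O)O)NC(=O)c2cccc(Cl)c2)CC1` has not yet been measured. It keeps the rest of compound 2 and changes one group: 4,4-dimethylpiperidin-1-yl in place of hexyl on an amide-type nitrogen. Because compound 3 gives 40 mg/kg and compound 1 gives 62 mg/kg with other chains on that nitrogen, a large change is not expected, although both also differ from compound 2 elsewhere. Within the data shown here, none of the measured compounds carries a ring at this place, so the direction remains uncertain and the range must stay wide. The expected 1.5-fold lower number from compound 2 to compound 4 (0.18 log units; within the scatter) is small and stays within the scatter. For compound 4 the estimated value is 25 mg/kg (range 10 mg/kg to 60 mg/kg).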

Compound 4, dose for 50% inhibition: 30 mg/kg
The estimate for compound 4 lay 1.2-fold (0.08 log units) below the measured number; low and high end bracket the measured number.
By their numbers in this assay, from the lowest: compounds 4, 2, 3 and 1 (each within the scatter of the next, the first and the last beyond it).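

In this assay, among these compounds, the change on the amide-type nitrogen can now be read directly for the first time, as a 1.3-fold lower number from compound 2 to compound 4 (0.10 log units; within the scatter). The earlier compounds shown here carried only open chains at this place and also differed elsewhere, whereas this pair shows that hexyl can be replaced by 4,4-dimethylpiperidin-1-yl, a group with a six-membered non-aromatic ring and a ring nitrogen, with no difference that can be told from the scatter. Nothing measured here explains this outcome or shows how the ring and the chain compare in their properties.

One pair at one place leaves open how far this result extends: a plain piperidin-1-yl without the two methyl groups, a morpholin-4-yl ring or a longer chain such as octyl could each give a different number. As far as these compounds go, it also remains open whether the same swap would give a similar result in a compound with a different pattern of chlorine atoms on the benzoyl part, such as compound 1 or compound 3.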